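This account rests on a few compounds, and the source may have more. Where it says the series, first, only, none or still open, it means among the compounds named here.

Compound 2, `Cc1c(C(=O)Nc2c(F)cc(-c3cccc(F)c3)cc2F)nc2ccc(F)cc2c1O`, belongs to a set of three amides that share one core and differ only in the substituent on the fused two-ring part. In a functional assay on A-375 cells (Homo sapiens) for antiproliferative activity, read by MTT assay, with a stated time of 24 h, tested at 0.14 ug/mL (a higher number here means a stronger effect of the compound at the concentration tested, a lower number a weaker effect), compound 2 gives 0%. Compound 1, `Cc1ccc2nc(C(=O)Nc3c(F)cc(-c4cccc(F)c4)cc3F)c(C)c(O)c2c1`, gives 1.06% in this assay, and compound 3, `CCOc1ccc2nc(C(=O)Nc3c(F)cc(-c4cccc(F)c4)cc3F)c(C)c(O)c2c1`, gives 1.54%. The step of a number 1.1 percentage points lower from compound 1 to compound 2 (within the scatter) and the step of a number 1.5 percentage points higher from compound 2 to compound 3 (within the scatter) both lie within the scatter, as does the step of a number 0.5 percentage points higher from compound 1 to compound 3 (within the scatter), so the three compounds cannot be told apart on these numbers, and compound 2 stands among them rather than apart from them.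

Compound 4, `Cc1c(C(=O)Nc2c(F)cc(-c3cccc(F)c3)cc2F)nc2ccc(OC(F)(F)F)cc2c1O`, differs from compound 2 by trifluoromethoxy in place of fluoro on an aromatic carbon. Among the compounds with values here, the step that bears most directly on this change is the one from compound 2 to compound 3, where an oxygen-linked group also took the place of fluoro at the same position and the step of a number 1.5 percentage points higher from compound 2 to compound 3 (within the scatter) stayed within the scatter; the step of a number 1.1 percentage points lower from compound 1 to compound 2 (within the scatter) shows that exchanging the group at this position likewise produced nothing beyond the scatter. Nothing in these data suggests that trifluoromethoxy in place of fluoro should behave differently, so no step beyond the scatter is expected in this assay.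

Compound 4 is therefore expected to give about 1.5%, within a range from 0% to 9%. This estimate means an expected step of a number 1.5 percentage points higher from compound 2 to compound 4 (within the scatter).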

Compound 4, a percentage reported as inhibition, at one concentration (the size of the read-out at that concentration, not a potency): 0.06%
For compound 4 the middle estimate is 1.4 percentage points above the measured one; measured number inside the range.
By their numbers in this assay, from the lowest: compounds 2, 4, 1 and 3 (each within the scatter of the next).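

At this position of the shared core, trifluoromethoxy in place of fluoro produces no separation in this assay, with a number 0.1 percentage points higher from compound 2 to compound 4 (within the scatter) and with the same outcome for trifluoromethyl in place of ethyl on the oxygen, a number 1.5 percentage points lower from compound 3 to compound 4 (within the scatter) and for trifluoromethoxy in place of methyl, a number 1 percentage points lower from compound 1 to compound 4 (within the scatter) in this comparison too. The position has now carried methyl, fluoro, ethoxy and trifluoromethoxy, and all four compounds remain within the scatter of one another, so adding a fluorinated oxygen-linked group still reveals no group that stands apart at the concentration tested. No accompanying measurement bears on this result.

As far as these compounds go, it remains open whether an amine or a carboxylic acid at this position would give a read-out beyond the scatter. Also open, from the compounds shown here alone, is whether changing another part of the core, such as replacing the hydroxyl, would separate these compounds.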